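Series notes: aryl replacement on the shared core

The compounds below may be only part of what the source reports. "The series", "measured", "known", "first", "only" and "open" are said of these compounds alone.

Three compounds share one core and differ only in the aryl group carried on the five-membered aromatic ring with 1 nitrogen and 1 sulfur. In an in vitro assay on HEK385-7 cells for displacement of a labelled ligand from prostaglandin D2 receptor 2 (Homo sapiens) (a higher number here means a weaker inhibitor, a lower number a stronger inhibitor), compound 1 `N#Cc1cc(-c2nc(C(c3ccc(F)cc3)c3ccc(F)cc3)sc2CC(=O)O)ccc1F` gives 57 nM, compound 2 `NS(=O)(=O)c1ccc(-c2nc(C(c3ccc(F)cc3)c3ccc(F)cc3)sc2CC(=O)O)cc1` gives 1500 nM, and compound 3 `O=C(O)Cc1sc(C(c2ccc(F)cc2)c2ccc(F)cc2)nc1-c1ccnc(N2CCC2)c1` gives 660 nM. Compound 3 stands second highest of the three numbers: the gap a 12-fold higher number from compound 1 to compound 3 (1.06 log units; beyond the scatter) is large, while the gap a 2.3-fold lower number from compound 2 to compound 3 (0.36 log units; beyond the scatter) is modest.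

Compound 4 `Cc1cc(-c2nc(C(c3ccc(F)cc3)c3ccc(F)cc3)sc2CC(=O)O)cnc1N` carries the change (6-amino-5-methylpyridin-3-yl in place of 2-(azetidin-1-yl)pyridin-4-yl on an aromatic carbon). Of the measured steps, those at the same position bear on it: a 12-fold higher number from compound 1 to compound 3 (1.06 log units; beyond the scatter) and a 2.3-fold lower number from compound 2 to compound 3 (0.36 log units; beyond the scatter), and also a 26-fold higher number from compound 1 to compound 2 (1.42 log units; beyond the scatter). They show that swapping the aryl group at this position moves this assay by modest to large amounts, with no measured case of a group that brings a hydrogen-bond donor (compound 2) doing better than compound 1. The new group brings 1 hydrogen-bond donor, as compound 2 does, which makes a gain beyond the scatter seem unlikely; the expected step of a 1.1-fold lower number from compound 3 to compound 4 (0.04 log units; within the scatter) is therefore small, in either direction, and may sit within the scatter. For compound 4 the estimate in this assay is 600 nM, with a range from 150 nM to 2500 nM.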

Compound 4, half-maximal inhibitory concentration: 880 nM
Compound 4: the middle estimate sits 1.5-fold (0.17 log units) below what was measured, within the range that was stated.
By their numbers in this assay, from the lowest: compound 1; then compounds 3, 4 and 2 (each within the scatter of the next, the first and the last beyond it).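

In this assay, the step of a 1.3-fold higher number from compound 3 to compound 4 (0.12 log units; within the scatter) lies within the scatter, so losing the four-membered non-aromatic ring of 2-(azetidin-1-yl)pyridin-4-yl and gaining the hydrogen-bond donor of 6-amino-5-methylpyridin-3-yl gives no readable change at this position. The step of a 1.7-fold lower number from compound 2 to compound 4 (0.23 log units; within the scatter) also lies within the scatter, while the step of a 15-fold higher number from compound 1 to compound 4 (1.19 log units; beyond the scatter) lies beyond it, so compound 4 joins compounds 2 and 3 as a third replacement that leaves a large gap to compound 1; hydrogen-bond donors do not sort these results, as compound 3 has none and still cannot be told apart from compound 4. No supporting data bear on why the 3-cyano-4-fluorophenyl group of compound 1 stands apart from these three groups.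

Still open, as far as these compounds go, is whether the nitrile or the fluorine of compound 1 carries its lower number, which a phenyl group bearing only one of the two would test. Also open, from the compounds shown here alone, is what the amine and the methyl of 6-amino-5-methylpyridin-3-yl each contribute, which a pyridine carrying only one of them would separate.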